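Aryl ketone versus benzyl ester on the exocyclic alkene

The source may report more compounds than this note shows. Statements on the series, on what has been measured and on what is new or still open speak of the compounds shown alone.

Compound 2 `CC1(C)S[C@@H]2/C(=C\C(=O)OCc3ccccc3)C(=O)N2[C@H]1C(=O)OC(c1ccccc1)c1ccccc1` gives 8200 nM in a functional assay on OE19 cells (Homo sapiens) for cytotoxicity, read by MTT assay, with a stated time of 48 h; on this read-out higher numbers stand for weaker inhibition and lower numbers for stronger inhibition. Going by the values given here, compound 1 `CC1(C)S[C@@H]2/C(=C\C(=O)c3ccc(Cl)cc3)C(=O)N2[C@H]1C(=O)OC(c1ccccc1)c1ccccc1` gives 14600 nM in this assay, and the only step on record, a 1.8-fold lower number from compound 1 to compound 2 (0.25 log units; within the scatter), sits within the scatter, so compound 2 and compound 1 are not separated by these numbers. Compound 3 `CC1(C)S[C@@H]2/C(=C\C(=O)c3ccc(Br)cc3)C(=O)N2[C@H]1C(=O)OC(c1ccccc1)c1ccccc1` differs from compound 2 by 4-bromophenyl in place of benzyloxy on a carbonyl carbon. This largely retraces that step, with 4-bromophenyl where compound 1 carries 4-chlorophenyl, so compound 3 is expected to move back toward the number of compound 1 by a step of a 1.5-fold higher number from compound 2 to compound 3 (0.17 log units; within the scatter) that stays within the scatter. The estimate for compound 3 in this assay is 12000 nM, range 5000 nM to 30000 nM.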

Compound 3, half-maximal inhibitory concentration: 13800 nM
The estimate for compound 3 lay 1.2-fold (0.06 log units) below the measured number, and the stated range covers the measured number.
By their numbers in this assay, from the lowest: compounds 2, 3 and 1 (each within the scatter of the next).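

Bromo in place of chloro on an aromatic carbon gives a 1.1-fold lower number from compound 1 to compound 3 (0.02 log units; within the scatter) in this assay, so these two halogens are not separated on the aryl ketone. Exchanging benzyloxy for 4-bromophenyl gives a 1.7-fold higher number from compound 2 to compound 3 (0.23 log units; within the scatter), so a second aryl ketone also stays unseparated from the benzyl ester. No supporting data bear on these results.

Open, as far as these compounds go, is whether an amine or a carboxylic acid in place of 4-bromophenyl would move the number beyond the scatter. Also open, from the compounds shown here alone, is whether a longer chain in place of benzyloxy would do so.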